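The source may hold more compounds than are shown below. What is called first, only, known or untested is meant among the compounds shown, and "the series" means these compounds.

Measured compounds:
compound 1, `COc1cc(/C=C/C(=O)c2cccc(-n3cc(-c4ccc(Cl)cc4)[nH]c3=O)c2)ccc1O`, 1850 nM;
compound 2, `COc1cc(/C=C/C(=O)c2cccc(-n3cc(-c4ccccc4)[nH]c3=O)c2)cc(OC)c1OC`, 1260 nM.

Both were tested in a functional assay on HCC 2998 cells (Homo sapiens) for inhibition; a higher number here means a weaker inhibitor of growth, a lower number a stronger inhibitor of growth. Compound 1 gives 1850 nM, the higher of the two numbers, while compound 2 gives 1260 nM; the gap between them lies within the scatter, so nothing can be said about an order between these two.

The next compound is compound 3, `COc1cc(/C=C/C(=O)c2cccc(-n3cc(-c4ccccc4)[nH]c3=O)c2)ccc1O`, not yet measured. It differs from compound 1 in one place: hydrogen in place of chloro on an aromatic carbon. Going by the values given here, no measured pair in the set shows this change, so its effect here is unknown. A change of this kind, with no ring, no donor or acceptor and no charge involved, is expected to leave the number close to that of compound 1, with a small lean toward a higher number, most likely inside the scatter. Compound 3 is therefore estimated at 2200 nM, with a range of 900 nM to 5000 nM, meaning an expected step of a 1.2-fold higher number from compound 1 to compound 3 (0.08 log units; within the scatter).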

Compound 3, concentration for 50% growth inhibition: 1510 nM
For compound 3 the middle estimate is 1.5-fold (0.16 log units) above the measured one, and the stated range covers the measured number.
By their numbers in this assay, from the lowest: compounds 2, 3 and 1 (each within the scatter of the next).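

In this assay, going by these compounds alone, the change from 4-chlorophenyl to phenyl gives a 1.2-fold lower number from compound 1 to compound 3 (0.09 log units; within the scatter), the first reading of this change. At this position, on an aromatic carbon para to a large group, chloro and hydrogen therefore cannot be told apart in this read-out, so the chloro is not required for a number in this range. Nothing available bears on why the step is this small.

Still open, as far as these compounds go, is whether a group of another kind at the same position, such as an amine, a carboxylic acid or a longer chain, would stay within the scatter of these numbers or move clearly away from them. This single step also leaves open whether the same change would read alike on a core with different substituents elsewhere.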